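The source may report more compounds than this note shows. Statements on the series, on what has been measured and on what is new or still open speak of the compounds shown alone.

Measured so far:
- compound 1, `Cc1nn(C)c(Oc2ccc(F)cc2)c1/C=N\CCCCCOc1cc2oc(=O)cc(C)c2cc1Cl`: > 25000 nM (a limit of the assay)
- compound 2, `Cc1nn(C)c(Oc2ccc(Br)cc2)c1/C=N\CCCCCOc1cc2oc(=O)cc(C)c2cc1Cl`: 13800 nM
- compound 3, `Cc1nn(C)c(Oc2ccccc2F)c1/C=N\CCCCCCOc1cc2oc(=O)cc(C)c2cc1Cl`: > 25000 nM (a limit of the assay)

All three share one core and were tested in a functional assay on HepG2 cells (Homo sapiens) for antiproliferative activity, read by MTT assay, with a stated time of 72 h; on this read-out lower numbers stand for stronger inhibition and higher numbers for weaker inhibition. For compound 1 only a limit is reported, > 25000 nM. Compound 2 gives 13800 nM. For the measured compounds named here, the one measured step between neighbours, an at least 1.8-fold lower number from compound 1 to compound 2 (0.25 log units; that floor lies within the scatter), is a halogen swap on the phenyl that hangs from the oxygen of the core. For compound 3 there is again only a limit, > 25000 nM. So compound 3 stands at the limit of > 25000 nM in this assay, at which 2 of the 3 values shown sit, together with compound 1, and no ordering among the three can be read beyond what the step from compound 1 to compound 2 shows.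

Compound 4, `Cc1nn(C)c(Oc2ccc(Cl)cc2)c1/C=N\CCCCCCOc1cc2oc(=O)cc(C)c2cc1Cl`, has not been measured in this assay. Its structure differs from compound 3 by 4-chlorophenyl in place of 2-fluorophenyl on an oxygen on an aromatic ring. Going by the values given here, only the step from compound 1 to compound 2 bears on such a change, and its floor lies within the scatter, so no step beyond the scatter is expected here. Compound 4 is therefore estimated at 22000 nM, within 8000 nM to 60000 nM, which means an expected step of an at least 1.1-fold lower number from compound 3 to compound 4 (0.05 log units; that floor lies within the scatter).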

Compound 4, half-maximal inhibitory concentration: 2960 nM
The estimate for compound 4 lay 7.4-fold (0.87 log units) above the measured number; the whole stated range lies above it.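

The phenyl group on the oxygen of the shared core can clearly matter. In this assay, putting 4-chlorophenyl in place of 2-fluorophenyl gives an at least 8.4-fold lower number from compound 3 to compound 4 (0.92 log units; beyond the scatter), a step that clears the usual scatter, which the earlier bromo-for-fluoro step could not be shown to do. Compound 3 and compound 4 carry the same chain, so this step belongs to that one group, and its true size may be larger, because compound 3 stands at a limit of the assay rather than at a number: the limit of > 25000 nM in this assay, at which 2 of the 4 values shown sit.

Both the kind of halogen and its place on the ring changed in this single swap, and the compounds shown cannot separate the two. On these data alone, how a plain phenyl without any halogen, or a phenyl carrying a methoxy group or an amine, would behave in this assay also remains open.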